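The compounds below may be only part of what the source reports. "The series", "measured", "known", "first", "only" and "open" are said of these compounds alone.

Compound 3, `Clc1ccc(COc2ccccc2/C=C/C(/C=C/c2ccccn2)=N/Oc2ncnc3cc(Cl)ccc23)c(Cl)c1`, stands lowest among the three compounds measured in a functional assay on SMMC-7721 cells (Homo sapiens) for inhibition, read by MTT assay, with a stated time of 72 h, tested at 1 uM; on this read-out lower numbers stand for a weaker effect and higher numbers for a stronger effect at the one concentration tested. In this assay compound 3 gives 23.6%, while compound 1, `Clc1ccc(COc2ccccc2/C=C/C(/C=C/c2ccccn2)=N/Oc2ncnc3cc(Cl)ccc23)cc1`, gives 94% and compound 2, `Clc1ccccc1COc1ccccc1/C=C/C(/C=C/c1ccccn1)=N/Oc1ncnc2ccccc12`, gives 95.7%. Among the compounds with values here, the only single-site step so far runs from compound 1 to compound 3, where a chloro replaced a hydrogen on an aromatic carbon, and the read-out fell by a number 70.4 percentage points lower from compound 1 to compound 3 (beyond the scatter). Compound 4, `Clc1ccc2c(O/N=C(\C=C\c3ccccn3)/C=C/c3ccccc3OCc3ccccc3Cl)ncnc2c1`, is the next compound to be tested, and it differs from compound 3 in one place: hydrogen in place of chloro on an aromatic carbon. This is the same kind of change as the measured step, taken in the opposite direction, turning a (2,4-dichlorobenzyl)oxy group back into a (2-chlorobenzyl)oxy group. The drop seen from compound 1 to compound 3 was large, so a step upward of similar size is expected, because a number 70.4 percentage points lower from compound 1 to compound 3 (beyond the scatter) points to the second chloro as the feature that went with the low number. Compound 4 is therefore estimated at 85%, with a range from 55% to 97%. The expected step from compound 3 to compound 4 is a number 61.4 percentage points higher from compound 3 to compound 4 (beyond the scatter).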

Compound 4, a percentage reported as inhibition, at one concentration (the size of the read-out at that concentration, not a potency): 94.8%
Compound 4: the middle estimate sits 9.8 percentage points below what was measured; the measured number falls inside the stated range.
By their numbers in this assay, from the lowest: compound 3; then compounds 1, 4 and 2 (each within the scatter of the next).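

Taking one chloro off the (2,4-dichlorobenzyl)oxy group of compound 3 gives a number 71.2 percentage points higher from compound 3 to compound 4 (beyond the scatter) in this assay, and the chloro removed here is not the one that separates compound 1 from compound 3, so the low number goes with the two chloro groups together, not with either one alone. Where the single chloro sits on that ring makes no difference that can be read, with a number 0.8 percentage points higher from compound 1 to compound 4 (within the scatter). The same swap made on the core instead leaves a number 0.9 percentage points lower from compound 2 to compound 4 (within the scatter), so what an added chloro does here depends on where it goes: the same change on two cores in this assay, a number 70.4 percentage points lower (beyond the scatter) from compound 1 to compound 3 and a number 0.9 percentage points lower (within the scatter) from compound 2 to compound 4, 69.5 percentage points apart, beyond the scatter of two such steps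

Going by these compounds, whether a fluoro or a methoxy group in place of either chloro of compound 3 would go with the same low number stays open. Compounds 1, 2 and 4 were read at one concentration only, so whether any of them would give a stronger or weaker effect at another concentration cannot be told.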